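Aryl amide swap on a sulfonamide series: compound 3

The source may hold more compounds than are shown below. What is called first, only, known or untested is meant among the compounds shown, and "the series" means these compounds.

Among the compounds with values here, compound 2 `CCCC(=O)N1CCC(NS(=O)(=O)c2ccc(NC(=O)c3cc(C)oc3C(F)(F)F)c3ccccc23)CC1` holds the lowest of the two numbers so far in an in vitro functional assay on CHO/Galpha16 cells for antagonist activity at C-C chemokine receptor type 8 (Homo sapiens), read by FLIPR (a lower number here means a stronger inhibitor, a higher number a weaker inhibitor), where compound 2 gives 46.9 nM; its nearest neighbour is compound 1 `CCCC(=O)N1CCC(NS(=O)(=O)c2ccc(NC(=O)c3ccc(F)cc3)c3ccccc23)CC1`, which in this assay gives 59.5 nM. Within the data shown here, the only measured step, a 1.3-fold lower number from compound 1 to compound 2 (0.10 log units; within the scatter), exchanged one aryl group for another on the carbonyl carbon and stayed within the scatter. Compound 3 `CCCC(=O)N1CCC(NS(=O)(=O)c2ccc(NC(=O)c3cccnc3)c3ccccc23)CC1` differs from compound 2 by pyridin-3-yl in place of 5-methyl-2-(trifluoromethyl)furan-3-yl on a carbonyl carbon. Among the measured compounds shown here, that step is of the same kind as the step from compound 1 to compound 2, so the measured data give no ground to expect a shift beyond the scatter in this assay; the estimated step for compound 3 is therefore a 1.5-fold higher number from compound 2 to compound 3 (0.17 log units; within the scatter), with a wide range because only one comparable step exists. Compound 3 is accordingly expected to give about 70 nM in this assay, between 25 nM and 200 nM.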

Compound 3, half-maximal inhibitory concentration: 885 nM
Compound 3: middle estimate off by 13-fold (1.10 log units), on the low side; the measured number lies above the stated range.
By their numbers in this assay, from the lowest: compounds 2 and 1 (each within the scatter of the next); then compound 3.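

In this assay the group on this carbonyl carbon proves far from interchangeable: pyridin-3-yl brings a 19-fold higher number from compound 2 to compound 3 (1.28 log units; beyond the scatter) and likewise a 15-fold higher number from compound 1 to compound 3 (1.17 log units; beyond the scatter) when it replaces 4-fluorophenyl. The earlier exchange, a 1.3-fold lower number from compound 1 to compound 2 (0.10 log units; within the scatter), had suggested tolerance, but the new result confines that tolerance to these two groups, and ring size does not sort them, since the six-membered 4-fluorophenyl matches the five-membered furan while the six-membered pyridine does not. The hydrogen-bond donor and acceptor counts of the group are also the same in compound 2 and compound 3, and no measurement shown explains the difference.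

On these data alone, it remains open whether the ring nitrogen alone separates compound 3 from compound 1. Plain phenyl, pyridin-4-yl or a fluorine-bearing pyridin-3-yl on the same carbonyl carbon would bear on that question.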